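The compounds below may be only part of what the source reports. "The series", "measured", "known", "first", "only" and "open" are said of these compounds alone.

Compound 1 `CC(C)(C)OC(=O)N1CCC(CCCNc2ccc3c(c2)C(=O)CO3)CC1`: 95%
Compound 2 `COC(=O)c1cnc(N2CCC(CCCNc3ccc4c(c3)OCC4=O)CC2)nc1`: 85%

In a functional assay on CHO-K1 cells for agonist activity at Glucose-dependent insulinotropic receptor (Homo sapiens), read by HTRF and cAMP accumulation, with a stated time of 30 min (a lower number here means a smaller maximal response, a higher number a larger maximal response), compound 2 gives 85%, and compound 1 gives 95%; the gap between the two lies within the usual scatter, so neither can be set apart from the other. Compound 3 `CC(C)c1nnc(N2CCC(CCCNc3ccc4c(c3)OCC4=O)CC2)o1` differs from compound 2 in a single place: 5-isopropyl-1,3,4-oxadiazol-2-yl in place of 5-(methoxycarbonyl)pyrimidin-2-yl on an amine nitrogen in a ring. Among the measured compounds shown here, no measured pair shows this change, so its effect in this assay is not known from the data. Because compound 2 already gives 85% and compound 1 gives 95%, the expected step of no change at the digits printed from compound 2 to compound 3 (within the scatter) is not beyond the scatter. Compound 3 is estimated at 85%, ranging from 65% to 100%.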

Compound 3, largest response reached (Emax), in percent of the reference or control that the assay uses: 85%
Compound 3: middle estimate and measured number agree at the digits printed; the range from low to high includes it.
By their numbers in this assay, from the lowest: compounds 2, 3 and 1 (each within the scatter of the next).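

In this assay putting 5-isopropyl-1,3,4-oxadiazol-2-yl in place of 5-(methoxycarbonyl)pyrimidin-2-yl on the amine nitrogen in a ring gives no change at the digits printed from compound 2 to compound 3 (within the scatter) and shows that the maximal response at this position holds with a five-membered aromatic ring as with a six-membered one. The entering group has fewer heavy atoms and no double bond outside aromatic rings. Nothing measured bears on why the response holds.

The compounds shown leave open how the response would stand with a carboxylic acid or an acetyl group on that nitrogen. From the compounds shown here alone, a longer chain to the shared core also remains open.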